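Ethoxy replaced by chloro: expected activity of compound 3

The compounds below may be only part of what the source reports. "The series", "measured", "known", "first", "only" and "open" are said of these compounds alone.

Going by the values given here, compound 2 `CCOc1ccc(-c2nn(-c3ccccc3)cc2C2=NOC3C(=O)N(C)C(=O)C23)cc1` stands highest of the two numbers so far in a functional assay on the whole organism (Abdomen, strain Swiss albino) with Mus musculus as the target, with stated times of 10 min and 5 min, at a dose of 15 mg/kg by the oral route; on this read-out lower numbers stand for a weaker effect and higher numbers for a stronger effect at the one dose given; compound 2 gives 22.8%. Its nearest neighbour is compound 1 `CN1C(=O)C2ON=C(c3cn(-c4ccccc4)nc3-c3ccc(Br)cc3)C2C1=O`, which in this assay gives 9.81%. Among the compounds with values here, the only measured step, a number 13 percentage points higher from compound 1 to compound 2 (beyond the scatter), is the single comparison available for judging the next change.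

Compound 3 `CN1C(=O)C2ON=C(c3cn(-c4ccccc4)nc3-c3ccc(Cl)cc3)C2C1=O` differs from compound 2 by chloro in place of ethoxy on an aromatic carbon. Chloro, like bromo, is a halogen in the same position, so the move is read as roughly undoing the gain seen in a number 13 percentage points higher from compound 1 to compound 2 (beyond the scatter), and the number is expected to fall back toward the level of compound 1, with a step beyond the scatter but of modest size. Compound 3 is therefore estimated at 12%, with a range of 4% to 22%. The step this expectation implies is a number 10.8 percentage points lower from compound 2 to compound 3 (beyond the scatter), downward.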

Compound 3, a percentage reported as activity, at one dose (the size of the read-out at that dose, not a potency): 7.84%
Beside the measured number, compound 3's estimate is 4.2 percentage points above it; the measured number falls inside the stated range.
By their numbers in this assay, from the lowest: compounds 3 and 1 (each within the scatter of the next); then compound 2.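

In this assay, chloro in place of ethoxy on the aromatic carbon gives a number 15 percentage points lower from compound 2 to compound 3 (beyond the scatter), so the higher number of compound 2 now stands against two halogens, not one. Chloro in place of bromo at the same place gives a number 2 percentage points lower from compound 1 to compound 3 (within the scatter), so the two halogens are not told apart on this read-out, and the series so far divides into ethoxy on one side and halogen on the other. No measurement at hand accounts for the difference between ethoxy and the halogens.

Open, going by these compounds, is whether the higher number belongs to ethoxy alone or also extends to methoxy, a longer alkoxy chain or an amine at this place. Fluoro and an unsubstituted phenyl would show whether the halogen level holds across the group or is simply the level of the bare ring.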